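A few compounds are considered here, and "the series" means these few. Any claim that something is new, unique, unknown or untested is made for them only; others in the source may bear on it.

Going by the values given here, in an ADME assay on the whole organism (Rattus norvegicus) for pharmacokinetics (on this read-out higher numbers stand for wider distribution into tissues and lower numbers for narrower distribution), compound 1 `Cc1ccc([C@H](C)NC(=O)Cn2nnc3ccccc3c2=O)cc1` gives 2.1 L/kg, the higher of the two numbers measured so far, while compound 2 `COc1cccc2nnn(CC(=O)N[C@@H](C)c3ccc(C)cc3)c(=O)c12` gives 0.4 L/kg. Compound 3 `COc1ccc2nnn(CC(=O)N[C@@H](C)c3ccc(C)cc3)c(=O)c2c1` has yet to be measured. Compared with compound 1, it carries methoxy in place of hydrogen on an aromatic carbon, (methoxy in place of hydrogen on an aromatic carbon). Among the compounds with values here, the one measured step with this same exchange, made at a different aromatic carbon, is a 5.3-fold lower number from compound 1 to compound 2 (0.72 log units; beyond the scatter), which lies beyond the scatter. That single step suggests the direction, but nothing measured shows how its size depends on where the methoxy sits. A drop in the same direction, somewhat smaller and less certain, is therefore expected, and the estimated change is a 2.3-fold lower number from compound 1 to compound 3 (0.37 log units; beyond the scatter). For compound 3, the estimated value is 0.9 L/kg, with an expected range of 0.35 L/kg to 2.2 L/kg.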

Compound 3, volume of distribution: 0.6 L/kg
The estimate for compound 3 lay 1.5-fold (0.18 log units) above the measured number; the measured number falls inside the stated range.
By their numbers in this assay, from the lowest: compounds 2 and 3 (each within the scatter of the next); then compound 1.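

In this assay, methoxy in place of hydrogen on this aromatic carbon, meta to a fused ring and para to a fused ring, also lowers the number: a 3.5-fold lower number from compound 1 to compound 3 (0.54 log units; beyond the scatter). The exchange at the other aromatic carbon gave a 5.3-fold lower number from compound 1 to compound 2 (0.72 log units; beyond the scatter), and compound 2 and compound 3 lie within the scatter of each other, so these two compounds show no difference between the two places. Nothing shown here accounts for the drop at either carbon.

Whether the drop belongs to methoxy in particular stays open, since the compounds shown do not tell how fluorine, an amine or a carboxylic acid on these carbons would read, or a longer chain such as ethoxy. Going by these compounds, whether the other aromatic carbons of this ring would follow the same direction also remains open.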